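A (tert-butoxycarbonyl)methoxy swap on compound 1

A few compounds are considered here, and "the series" means these few. Any claim that something is new, unique, unknown or untested is made for them only; others in the source may bear on it.

Values measured in a functional assay for inhibition, with Homo sapiens as the target; on this read-out lower numbers stand for stronger inhibition and higher numbers for weaker inhibition:
Compound 1 `O=C(O)CCCCCCCn1nc(-c2ccccc2)c(-c2ccccc2)c1-c1ccccc1`: 3400 nM
Compound 2 `O=C(O)CCCCCCCn1cc(-c2ccccc2)c(-c2ccccc2)n1`: > 85000 nM, a limit of the assay

Going by the values given here, compound 1 holds the only true number in this assay. The result for compound 2 is > 85000 nM, which is a limit.

Compound 3 `CC(C)(C)OC(=O)COCCCCCCn1nc(-c2ccccc2)c(-c2ccccc2)c1-c1ccccc1` is still unmeasured. In it, (tert-butoxycarbonyl)methoxy stands in place of carboxymethyl on a saturated chain carbon, six bonds along the chain from an aromatic nitrogen ((tert-butoxycarbonyl)methoxy in place of carboxymethyl on a saturated chain carbon, six bonds along the chain from an aromatic nitrogen).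

Among the compounds with values here, only one measured step exists, and it lies elsewhere: an at least 25-fold higher number from compound 1 to compound 2 (1.39 log units; beyond the scatter), with hydrogen in place of phenyl on an aromatic carbon. It bears only indirectly, showing that a single change can move the number a long way. Within the data shown here, no measured step touches the chain. A move towards weaker inhibition is expected, estimated as a 7.4-fold higher number from compound 1 to compound 3 (0.87 log units; beyond the scatter). For compound 3 the estimate is 25000 nM, with an expected range of 5000 nM to 85000 nM.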

Compound 3, half-maximal inhibitory concentration: > 62000 nM
Compound 3: no number, only a limit; the forecaster's own chance of this, stated with the estimate: 40%; middle value at least 2.4-fold (0.39 log units) from the limit.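

In this assay, compound 3 gives > 62000 nM, which is a limit and not a number. With (tert-butoxycarbonyl)methoxy in place of carboxymethyl on a saturated chain carbon, six bonds along the chain from an aromatic nitrogen, the result is an at least 18-fold higher number from compound 1 to compound 3 (1.26 log units; beyond the scatter). The chain therefore matters as well as the phenyl group changed in compound 2, since the core of compound 1 is kept whole here and still no number is obtained, so the full size of the step cannot be read: the limit of > 62000 nM in this assay, at which 1 of the 3 values shown sits.

The compounds shown leave open whether this step follows from the tert-butyl ester or from the ether oxygen in the chain. A carboxylic acid on the same ether chain, or a methyl ester on the chain of compound 1, would tell the two apart.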